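Aryl substituent and cytotoxicity in a small series

A few compounds are considered here, and "the series" means these few. Any claim that something is new, unique, unknown or untested is made for them only; others in the source may bear on it.

compound 1, `Cc1cccc(NC(=S)OCCc2ccccn2)c1`: > 100000 nM
compound 2, `CCc1ccc(NC(=S)OCCc2ccccn2)cc1`: 44000 nM

In an ADME assay on MT4 cells (Homo sapiens) for cytotoxicity, read by MTT assay (on this read-out higher numbers stand for lower toxicity in this test and lower numbers for higher toxicity in this test), compound 2 gives 44000 nM. For compound 1 the entry is a limit of the assay rather than a number: compound 1 gives > 100000 nM. Going by the values given here, compound 2 therefore holds the only number among the two values shown, the other being a limit (the limit of > 100000 nM in this assay, at which 1 of the 2 values shown sits). Among the compounds with values here, no measured pair differs in a single place, so no measured step is available to set a scale for the series.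

Compound 3, `N#Cc1ccc(NC(=S)OCCc2ccccn2)cc1`, remains to be measured. It differs from compound 2 by cyano in place of ethyl on an aromatic carbon. Within the data shown here, with no measured step to lean on, the expectation is a modest rise in this assay, of a size near the edge of the usual scatter, and with a real chance that compound 3 returns only a limit. Compound 3 is estimated at 70000 nM, within a range from 25000 nM to 200000 nM. The expected step from compound 2 to compound 3 is a 1.6-fold higher number from compound 2 to compound 3 (0.20 log units; within the scatter).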

Compound 3, half-maximal cytotoxic concentration: 45000 nM
Beside the measured number, compound 3's estimate is 1.6-fold (0.19 log units) above it, within the range that was stated.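

Working notes: in this assay the series now has its first single-place step, with cyano in place of ethyl on an aromatic carbon, para to a large group, giving a 1.0-fold higher number from compound 2 to compound 3 (0.01 log units; within the scatter). At this position, then, the exchange of ethyl for cyano, which brings in a triple bond outside aromatic rings and a hydrogen-bond acceptor while keeping the count of heavy atoms, leaves the two compounds indistinguishable in this test, and compound 3 returns a number rather than a limit. No measurement at hand gives a reason for this outcome.

Whether an amine, a carboxylic acid or a longer chain such as butyl at this same position would produce a step beyond the scatter stays open, as the one step shown covers only the exchange of ethyl and cyano. From the compounds shown here alone, compound 1 gives > 100000 nM, which is a limit of the assay, and it differs from compound 2 and compound 3 in more than one place, so the role of the place of the substituent on the aromatic ring also stays open.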